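The source may report more compounds than this note shows. Statements on the series, on what has been measured and on what is new or still open speak of the compounds shown alone.

Measured compounds in a functional assay on EOL1 cells (Homo sapiens) for inhibition, read by fluorescence, with a stated time of 72 h; a lower number here means a stronger inhibitor of growth, a higher number a weaker inhibitor of growth:
compound 1, `CCCCCCn1cnc2c(Nc3ccc(Cl)cc3)nc(N[C@H]3CC[C@H](N)CC3)nc21`: 440 nM
compound 2, `CCCCCCn1cnc2c(Nc3cccc(Cl)c3)nc(N[C@H]3CC[C@H](N)CC3)nc21`: 310 nM
compound 3, `CCCCn1cnc2c(Nc3ccc(Cl)cc3)nc(N[C@H]3CC[C@H](N)CC3)nc21`: 50 nM

Compound 3 has the lowest of the three numbers in this assay; it differs from compound 1 by hydrogen in place of ethyl on a saturated chain carbon, four bonds along the chain from an aromatic nitrogen, a change that gave an 8.8-fold lower number from compound 1 to compound 3 (0.94 log units; beyond the scatter). Compound 4, `CCCCn1cnc2c(Nc3cccc(Cl)c3)nc(N[C@H]3CC[C@H](N)CC3)nc21`, is not yet measured. It differs from compound 3 by 3-chlorophenyl in place of 4-chlorophenyl on a nitrogen on an aromatic ring. The same change, (3-chlorophenyl in place of 4-chlorophenyl on a nitrogen on an aromatic ring), on the core of compound 1 gave a 1.4-fold lower number from compound 1 to compound 2 (0.15 log units; within the scatter). The account of compound 4 rests on that single measured pair, so the step is expected to be small again: from compound 3 to compound 4 the expected step in this assay is a 1.3-fold lower number from compound 3 to compound 4 (0.10 log units; within the scatter), because of a 1.4-fold lower number from compound 1 to compound 2 (0.15 log units; within the scatter). Compound 4 is therefore estimated at 40 nM in this assay, expected between 15 nM and 110 nM.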

Compound 4, concentration for 50% growth inhibition: 160 nM
Beside the measured number, compound 4's estimate is 4.0-fold (0.60 log units) below it; the whole stated range lies below it.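

In this assay, 3-chlorophenyl in place of 4-chlorophenyl gave a 3.2-fold higher number from compound 3 to compound 4 (0.51 log units; beyond the scatter), so the result of this change depended on the core carrying it: the same change on two cores in this assay, a 1.4-fold lower number (0.15 log units; within the scatter) from compound 1 to compound 2 and a 3.2-fold higher number (0.51 log units; beyond the scatter) from compound 3 to compound 4, 4.5-fold (0.66 log units) apart, beyond the scatter of two such steps Hydrogen in place of ethyl on the chain gave a 1.9-fold lower number from compound 2 to compound 4 (0.29 log units; within the scatter), and this change did not carry over at the same size either: the same change on two cores in this assay, an 8.8-fold lower number (0.94 log units; beyond the scatter) from compound 1 to compound 3 and a 1.9-fold lower number (0.29 log units; within the scatter) from compound 2 to compound 4, 4.5-fold (0.66 log units) apart, beyond the scatter of two such steps With one pair on each core, this shows that the two changes do not act independently across these four compounds, but it does not show why, or how either change would behave on any other core.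

The compounds shown leave open how a pentyl or propyl chain would fit this picture. They also leave open whether a bromophenyl or plain phenyl group would show the same dependence on the chain.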